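Swapping an Aromatic Ether Arm for a Plain Hexyl Chain

The source may hold more compounds than are shown below. What is called first, only, known or untested is meant among the compounds shown, and "the series" means these compounds.

Compound 1, `CCCCCOCNc1n[n+]([O-])c2ccccc2[n+]1[O-]`: 14500 nM
Compound 2, `COc1ccc(COCNc2n[n+]([O-])c3ccccc3[n+]2[O-])cc1`: 20100 nM

Both compounds share one core and differ only in the group on a saturated chain carbon bound to an oxygen on a saturated carbon. In a functional assay on K562 cells (Homo sapiens) for cytotoxicity, read by MTT assay, with a stated time of 72 h (a higher number here means a weaker inhibitor, a lower number a stronger inhibitor), compound 2 gives 20100 nM, the highest of the two numbers, yet its nearest neighbour is compound 1 at a 1.4-fold higher number from compound 1 to compound 2 (0.14 log units; within the scatter), so the two cannot be separated. Compound 3 `CCCCCCCOCNc1n[n+]([O-])c2ccccc2[n+]1[O-]` has not yet been measured. It differs from compound 2 as follows: hexyl in place of 4-methoxyphenyl on a saturated chain carbon bound to an oxygen on a saturated carbon. Within the data shown here, the only step that bears on this change is a 1.4-fold higher number from compound 1 to compound 2 (0.14 log units; within the scatter), where 4-methoxyphenyl in place of butyl, a chain close to hexyl, left the number within the scatter. For compound 3 a step of a 1.5-fold lower number from compound 2 to compound 3 (0.19 log units; within the scatter) is therefore expected, no larger than the scatter. Compound 3 is estimated at 13000 nM, within 5000 nM to 35000 nM.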

Compound 3, half-maximal inhibitory concentration: 2970 nM
Beside the measured number, compound 3's estimate is 4.4-fold (0.64 log units) above it, and the stated range ends above it.
By their numbers in this assay, from the lowest: compound 3; then compounds 1 and 2 (each within the scatter of the next).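

In this assay this position proves sensitive to the group it carries: hexyl in place of 4-methoxyphenyl gives a 6.8-fold lower number from compound 2 to compound 3 (0.83 log units; beyond the scatter) and so separates two groups in a way the earlier pair, with butyl, did not. Chain length alone also matters here, as ethyl in place of hydrogen on a saturated chain carbon, five bonds along the chain from an oxygen on a saturated carbon, gives a 4.9-fold lower number from compound 1 to compound 3 (0.69 log units; beyond the scatter) and sets hexyl apart from butyl. Nothing available here explains why the longer chain gives the lower number.

From the compounds shown here alone, whether a longer chain still, such as octyl or decyl, would lower the number further or reverse the trend remains open. So does whether a hexyl chain carrying an amine or a carboxylic acid would keep the number of compound 3.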